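Cutting the alkenyl ether of compound 1 to methoxy

The compounds below may be only part of what the source reports. "The series", "measured", "known", "first", "only" and "open" are said of these compounds alone.

compound 1 `C=CCCCCOc1ccccc1-c1cnc(OCCCC=C)n1C`: 4000 nM
compound 2 `C=CCCCCOc1ncc(-c2cccc(OC)c2OC)n1C`: 11000 nM

Both values come from a functional assay on LoVo cells (Homo sapiens) for inhibition, read by colorimetric assay and MTT assay, with a stated time of 72 h; a lower number here means a stronger inhibitor, a higher number a weaker inhibitor. Compound 1 gives 4000 nM, the lower of the two numbers, and compound 2 gives 11000 nM. The gap between them lies beyond the usual scatter of repeated measurements.

The next compound to be read is compound 3 `C=CCCCCOc1ccccc1-c1cnc(OC)n1C`. Its structure differs from that of compound 1 as follows: hydrogen in place of but-3-en-1-yl on a saturated chain carbon bound to an oxygen on an aromatic ring. Cut one bond further out, the same difference reads (pent-4-en-1-yl)oxy to methoxy.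

Within the data shown here, no measured pair isolates this change, so the data set no size for the step. Among the measured compounds shown here, compound 1 at 4000 nM is the lowest number so far, so the expectation in this assay leans toward a moderate step to a higher number, although a step within the scatter remains possible. The range is kept wide for that reason.

The estimated value for compound 3 is 10000 nM, with an expected range of 3500 nM to 30000 nM.

The expected change is a 2.5-fold higher number from compound 1 to compound 3 (0.40 log units; beyond the scatter).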

Compound 3, half-maximal inhibitory concentration: 47000 nM
The estimate for compound 3 lay 4.7-fold (0.67 log units) below the measured number, and the stated range ends below it.
By their numbers in this assay, from the lowest: compound 1; then compound 2; then compound 3.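

In this assay, among these compounds, going from (pent-4-en-1-yl)oxy to methoxy on the core of compound 1 gives a large step (a 12-fold higher number from compound 1 to compound 3 (1.07 log units; beyond the scatter)), the first sized step, so this position is far from indifferent to the change. The piece that leaves, but-3-en-1-yl, is made of carbon only, with one double bond outside aromatic rings, no hydrogen-bond donors or acceptors and no net charge, so the loss of a purely hydrocarbon piece is enough for a step of this size at this place. No measurement in hand accounts for the size of the step, and the reading rests on this one pair.

The compounds shown do not separate the length of the chain from its double bond, so a saturated pentyl chain, a propyl chain of intermediate length or a longer chain would each be needed to tell whether the number follows chain length, the alkene or both. They also leave open how this position responds to a chain ending in an amine or a carboxylic acid in place of the terminal alkene.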